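The compounds below may be only part of what the source reports. "The series", "measured", "known", "first", "only" and "open" are said of these compounds alone.

Compound 2 `COc1ccc(-c2cc(C(C)=O)c3[nH]c(-c4ccc(F)cc4)cc3c2)cc1` gives 14.8% in a functional assay on MCF7 cells (Homo sapiens) for cytotoxicity, read by MTT assay, with a stated time of 2 days, tested at 100 uM (a higher number here means a weaker effect of the compound at the concentration tested, a lower number a stronger effect), the lowest of the two numbers in hand. Compound 1 `CC(=O)c1cc(-c2ccc(F)cc2)cc2cc(-c3ccc(F)cc3)[nH]c12` gives 20% in this assay, and the step of a number 5.2 percentage points lower from compound 1 to compound 2 (within the scatter) stays within the scatter. Compound 3 `COc1ccc(-c2cc(C(C)=O)c3[nH]c(-c4ccc(OC)cc4)cc3c2)cc1` differs from compound 2 by methoxy in place of fluoro on an aromatic carbon. Within the data shown here, the only step that bears on this change is the one just described, the same exchange made elsewhere in the molecule, and it was small. Compound 3 is therefore expected to give about 12% in this assay, between 2% and 28%. The estimated step of a number 2.8 percentage points lower from compound 2 to compound 3 (within the scatter) is expected to stay within the scatter.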

Compound 3, a percentage reported as activity, at one concentration (the size of the read-out at that concentration, not a potency): 39.9%
Compound 3: middle estimate off by 27.9 percentage points, on the low side, and the stated range ends below it.
By their numbers in this assay, from the lowest: compounds 2 and 1 (each within the scatter of the next); then compound 3.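

The exchange of 4-fluorophenyl to 4-methoxyphenyl does not behave alike at its two places in the molecule: in this assay, the step of a number 25.1 percentage points higher from compound 2 to compound 3 (beyond the scatter) lies beyond the scatter, whereas the step of a number 5.2 percentage points lower from compound 1 to compound 2 (within the scatter) does not. This position is therefore sensitive to the change in a way the earlier pair did not reveal. No measurement in hand explains the difference.

Open, from the compounds shown here alone, is whether the step would be the same without the methoxy already present elsewhere in the molecule. Also open, going by these compounds, is how an amine or a hydroxy group would read at this position.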